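The compounds below may be only part of what the source reports. "The series", "measured", "known", "first", "only" and "open" are said of these compounds alone.

Measured so far:
- compound 1, `N#Cc1cc(NCc2ccccc2[N+](=O)[O-])c2cn[nH]c2c1`, in an assay for inhibition of Tryptophan 2,3-dioxygenase (Homo sapiens), with stated times of 10 min and 60 min, tested at 100 uM (on this read-out lower numbers stand for a weaker effect and higher numbers for a stronger effect at the one concentration tested), gives 41%
- compound 2, `COC(=O)c1cc(NCc2ccccc2[N+](=O)[O-])c2cn[nH]c2c1`, in this assay gives 20%

Compound 2 stands lowest of the two numbers; its nearest neighbour is compound 1, whose number lies higher by the step of a number 21 percentage points lower from compound 1 to compound 2 (beyond the scatter).

Compound 3, `O=[N+]([O-])c1ccccc1CNc1cc(Br)cc2[nH]ncc12`, has not been measured. It differs from compound 2 in one place: bromo in place of methoxycarbonyl on an aromatic carbon.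

Among the measured compounds shown here, only one measured step exists here, and it concerns a different exchange: cyano giving way to methoxycarbonyl produced a modest fall, a number 21 percentage points lower from compound 1 to compound 2 (beyond the scatter), beyond the scatter. For the measured compounds named here, no measured pair shows bromo entering or methoxycarbonyl leaving for a single atom, so the expectation for this assay rests on the size of that one step alone. Because removing the methoxycarbonyl reverses the change that gave a number 21 percentage points lower from compound 1 to compound 2 (beyond the scatter), compound 3 is expected to climb back part of the way toward compound 1, a step of a number 15 percentage points higher from compound 2 to compound 3 (beyond the scatter). Compound 3 is therefore estimated at 35%, with a range from 15% to 55%.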

Compound 3, a percentage reported as inhibition, at one concentration (the size of the read-out at that concentration, not a potency): 64%
The estimate for compound 3 lay 29 percentage points below the measured number; measured number above the stated range.
By their numbers in this assay, from the lowest: compound 2; then compound 1; then compound 3.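

In this assay, putting bromo in place of methoxycarbonyl on this aromatic carbon gives a number 44 percentage points higher from compound 2 to compound 3 (beyond the scatter) and putting bromo in place of cyano gives a number 23 percentage points higher from compound 1 to compound 3 (beyond the scatter) on the same read-out. Among the compounds shown here, the earlier pair showed only that the number moves with the group at this position; now a single bromine atom, replacing the four heavy atoms of methoxycarbonyl, carries the number past that of the cyano compound, and compound 3 stands highest of the three. Nothing available here explains this rise.

Going by these compounds, what chloro, an amine or a carboxylic acid would do on this carbon stays open. So does whether the rise belongs to bromo in particular or would come with any single atom there.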